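Nitro in Place of Methyl on the Aromatic Ring

The source may report more compounds than this note shows. Statements on the series, on what has been measured and on what is new or still open speak of the compounds shown alone.

Of the compounds shown here, three on a shared core have been measured in an ADME assay on L929 cells (Mus musculus) for antiproliferative activity, read by CCK-8 assay, with a stated time of 48 h; on this read-out lower numbers stand for stronger inhibition and higher numbers for weaker inhibition. Compound 1 `CCCCCCSc1n[nH]c(-n2[se]c3ccccc3c2=O)n1` gives 39300 nM in this assay. Compound 3 `CCCSc1n[nH]c(-n2[se]c3ccccc3c2=O)n1` gives 31800 nM, and the step of a 1.2-fold lower number from compound 1 to compound 3 (0.09 log units; within the scatter) lies within the scatter. Compound 2 `Cc1ccc(CSc2n[nH]c(-n3[se]c4ccccc4c3=O)n2)cc1` returns only a limit of the assay, > 50000 nM, not a number. The steps of an at least 1.2-fold higher number from compound 1 to compound 2 (0.10 log units; that floor lies within the scatter) and an at least 1.5-fold lower number from compound 2 to compound 3 (0.19 log units; that floor lies within the scatter) both change the group on the saturated chain carbon bound to a sulfur, and both carry floors within the scatter because of the limit of > 50000 nM in this assay, at which 1 of the 3 values shown sits.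

Compound 4 `O=c1c2ccccc2[se]n1-c1nc(SCc2ccc([N+](=O)[O-])cc2)n[nH]1` differs from compound 2 by nitro in place of methyl on an aromatic carbon. Among the measured compounds shown here, no measured step touches a group on the aromatic ring; all of them alter the group on the saturated chain carbon bound to a sulfur, so none bears directly on this change. The writer therefore expects no step beyond the scatter in this assay, with the added uncertainty that compound 2 itself stands at a limit. He estimates compound 4 at 50000 nM, between 25000 nM and 100000 nM. This is expected to amount to the step of a number no higher from compound 2 to compound 4 (the limit leaves the size open).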

Compound 4, half-maximal inhibitory concentration: 7430 nM
The estimate for compound 4 lay 6.7-fold (0.83 log units) above the measured number, outside the stated range (below it).
By their numbers in this assay, from the lowest: compound 4; then compounds 3 and 1 (each within the scatter of the next). At a limit, above all of these: compound 2.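

In this assay, among the compounds shown here, the group on the aromatic ring proves to count for more than anything the earlier compounds showed: their steps changed only the group on the saturated chain carbon bound to a sulfur and none went beyond the scatter, whereas nitro in place of methyl on an aromatic carbon gives an at least 6.7-fold lower number from compound 2 to compound 4 (0.82 log units; beyond the scatter). Compound 2 stands at a limit of the assay, > 50000 nM, not a number. The full size of this step therefore stays open, because only its floor can be read: the limit of > 50000 nM in this assay, at which 1 of the 4 values shown sits.

As far as these compounds go, this single pair is all that speaks for the place para to a large group, so it remains open whether the lower number is particular to nitro. The compounds shown do not tell how an amine, a nitrile or a carboxylic acid would read at that place.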